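The source may hold more compounds than are shown below. What is called first, only, known or untested is meant among the compounds shown, and "the series" means these compounds.

The measured compounds:
Compound 1, `O=C(COc1ccc(/C=C2\SC(=O)NC2=O)cc1)Nc1ccc(F)cc1`, in a functional assay on PC-3 cells (Homo sapiens) for inhibition (on this read-out lower numbers stand for stronger inhibition of growth and higher numbers for weaker inhibition of growth), gives > 100000 nM, which is a limit of the assay and not a number.
Compound 2, `Cc1ccc(NC(=O)COc2ccc(/C=C3\SC(=O)NC3=O)cc2)cc1Cl`, in this assay gives > 100000 nM, again only a limit.

Compound 2 thus stands at the limit of this assay, as the limit of > 100000 nM in this assay, at which 2 of the 2 values shown sit, records; no numerical position is known for it. Among the measured compounds shown here, the single measured step, a step that the two limits leave unreadable from compound 1 to compound 2, runs between two limits and its size cannot be read.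

Compound 3, `O=C(COc1ccc(/C=C2\SC(=O)NC2=O)cc1)Nc1c(F)cc(Br)cc1F`, has not yet been measured in this assay. It differs from compound 2 by 4-bromo-2,6-difluorophenyl in place of 3-chloro-4-methylphenyl on an amide-type nitrogen. For the measured compounds named here, the only step that bears on this change is a step that the two limits leave unreadable from compound 1 to compound 2, and that one is unreadable, so the measured data give neither a size nor a direction for the step to be expected in this assay. Both measured compounds sit at the limit, and nothing in the data suggests the new aryl group would move compound 3 away from it. Compound 3 is therefore expected to give 100000 nM in this assay, with a range from 30000 nM to 300000 nM. The step this estimate means is a number no higher from compound 2 to compound 3 (the limit leaves the size open), expected to lie within the scatter.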

Compound 3, concentration for 50% growth inhibition: > 100000 nM
Compound 3: no number, only a limit (the forecaster's own chance of this, stated with the estimate: 75%); the middle value sits exactly at the limit.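

Compound 3, like compound 1 and compound 2, yields only a limit in this assay, so no step among these three compounds can be read, and their order stays unknown: the limit of > 100000 nM in this assay, at which 3 of the 3 values shown sit.

The compounds shown leave open how far any of these aryl groups on the amide-type nitrogen would shift growth inhibition, since no numerical value is available here.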